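The source may hold more compounds than are shown below. What is called first, only, known or untested is meant among the compounds shown, and "the series" means these compounds.

Working notes on the series in a functional assay on Jurkat cells (Homo sapiens) for cytotoxicity, read by MTT assay, with a stated time of 72 h; a higher number here means a weaker inhibitor, a lower number a stronger inhibitor. Of the compounds shown here, two have numbers so far. Compound 1 `O=C(Nc1ccc(Cl)cc1)Nc1ccc(C(=O)NO)cc1` gives 1060 nM in this assay, and compound 2 `O=C(Nc1ccc(C(=O)NO)cc1)Nc1ccc([N+](=O)[O-])cc1` gives 12700 nM. Among the compounds with values here, the single measured step between them, a 12-fold higher number from compound 1 to compound 2 (1.08 log units; beyond the scatter), is the only comparison available, and it concerns the ring that carries the nitro group. Within the data shown here, compound 2 therefore stands at the highest of the two numbers, with compound 1 as its only neighbour, the gap between them lying beyond the scatter.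

Compound 3 `O=C(/C=C/c1ccc(NC(=O)Nc2ccc([N+](=O)[O-])cc2)cc1)NO` is next in line. The change from compound 2 is 2-(hydroxycarbamoyl)ethenyl in place of hydroxycarbamoyl on an aromatic carbon; the group on the other ring, the nitro, stays as in compound 2. Among the measured compounds shown here, no measured step touches this position: the one step in hand alters a different part of the molecule and gives no guide, in either direction, for lengthening the hydroxycarbamoyl side by two carbons into the 2-(hydroxycarbamoyl)ethenyl chain. The expectation for compound 3 in this assay is thus loosely held, with the estimated step of a 2.5-fold lower number from compound 2 to compound 3 (0.40 log units; beyond the scatter) leaning toward a lower number than compound 2 but a wide range. Compound 3 is estimated at 5000 nM, expected between 1000 nM and 25000 nM.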

Compound 3, half-maximal inhibitory concentration: 90 nM
For compound 3 the middle estimate is 56-fold (1.74 log units) above the measured one; measured number outside the range, below it.
By their numbers in this assay, from the lowest: compound 3; then compound 1; then compound 2.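

In this assay the side bearing the hydroxycarbamoyl group proves highly sensitive: 2-(hydroxycarbamoyl)ethenyl in place of hydroxycarbamoyl gives a 140-fold lower number from compound 2 to compound 3 (2.15 log units; beyond the scatter) with the nitro group unchanged, a larger change than a 12-fold higher number from compound 1 to compound 2 (1.08 log units; beyond the scatter) on the other ring. The swap leaves the counts of hydrogen-bond donors and acceptors the same and introduces no net charge, so the groups differ in their added carbon atoms and a further double bond outside the aromatic rings. Nothing at hand accounts for the size of this step.

The compounds shown do not separate the added chain length from the added double bond, a question that the saturated 2-(hydroxycarbamoyl)ethyl chain or a longer unsaturated chain would address. They also leave open whether the step carries over to a chloro group on the other ring, and whether the large shift depends on the hydroxycarbamoyl end, as a carboxylic acid on the same ethenyl chain would show.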